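This account rests on a few compounds, and the source may have more. Where it says the series, first, only, none or still open, it means among the compounds named here.

Measured in a functional assay on Jurkat cells (Homo sapiens) for inhibition, read by MTT assay, with a stated time of 72 h; a higher number here means a weaker inhibitor, a lower number a stronger inhibitor:
compound 1 `C=C(Br)C(=O)Nc1cccc(/C=C/C(=O)Nc2ccc(F)cc2)c1`: 6200 nM
compound 2 `C=C(Br)C(=O)Nc1cccc(/C=C/C(=O)Nc2cccc(F)c2)c1`: 1000 nM
compound 3 `C=C(Br)C(=O)Nc1cccc(/C=C/C(=O)NCc2ccc(C)cc2)c1`: 740 nM

Compound 1 has the highest number of the three, which makes it the weakest inhibitor here. Compound 4 `C=C(Br)C(=O)Nc1cccc(/C=C/C(=O)Nc2ccc(OCC)cc2)c1` keeps the core of compound 1 but has ethoxy in place of fluoro on an aromatic carbon. Going by the values given here, no measured step makes this exact change. The closest evidence comes from two other changes to the group on the amide nitrogen: a 6.2-fold lower number from compound 1 to compound 2 (0.79 log units; beyond the scatter) and an 8.4-fold lower number from compound 1 to compound 3 (0.92 log units; beyond the scatter). Both are modest and both go downward. Three compounds are thin evidence, so a smaller move to a lower number is expected in this assay, a 2.5-fold lower number from compound 1 to compound 4 (0.39 log units; beyond the scatter). Compound 4 is estimated at 2500 nM, with an expected range of 800 nM to 7000 nM.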

Compound 4, half-maximal inhibitory concentration: 930 nM
The estimate for compound 4 lay 2.7-fold (0.43 log units) above the measured number; the measured number falls inside the stated range.
By their numbers in this assay, from the lowest: compounds 3, 4 and 2 (each within the scatter of the next); then compound 1.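

In this assay, keeping the ring and the position para to a large group but putting ethoxy in place of fluoro gives a 6.7-fold lower number from compound 1 to compound 4 (0.82 log units; beyond the scatter). So a change at this same position, with no move of the group and no change to the link at the amide nitrogen, is enough to bring compound 4 within the scatter of compounds 2 and 3. No evidence here explains this step. Going by these compounds, it remains open whether the fluoro's departure or the ethoxy's arrival matters more. Methoxy, a longer chain such as butoxy, or an amine at this position could help separate the two.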